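A few compounds are considered here, and "the series" means these few. Any claim that something is new, unique, unknown or untested is made for them only; others in the source may bear on it.

Measured so far in an assay on isolated protein for inhibition of high affinity 3',5'-cyclic-AMP phosphodiesterase 7A (Homo sapiens), read by cAMP accumulation, with a stated time of 10 min; a lower number here means a stronger inhibitor, a higher number a weaker inhibitor:
compound 1 `COc1nc2c(c(=O)n(C)c(=O)n2C)n1CCCC(=O)Nc1ccc(Cl)cc1` gives > 200000 nM
compound 2 `COc1nc2c(c(=O)n(C)c(=O)n2C)n1CCCC(=O)Nc1ccc(C(C)C)cc1` gives > 200000 nM
compound 3 `CCOc1nc2c(c(=O)n(C)c(=O)n2C)n1CC(=O)Nc1ccc(Cl)cc1` gives > 200000 nM

Each of these three values is a limit of this assay, not a number; compound 1 stops at it, compound 2 stops at it, and compound 3 stops at it. Compound 1 and compound 2 differ by one change, (isopropyl in place of chloro on an aromatic carbon), and the step that the two limits leave unreadable from compound 1 to compound 2 cannot be sized because both values sit at the limit of > 200000 nM in this assay, at which 3 of the 3 values shown sit. Compound 4 `CCOc1nc2c(c(=O)n(C)c(=O)n2C)n1CC(=O)Nc1ccc(C(C)C)cc1` has not been measured. It stands to compound 3 as compound 2 stands to compound 1, by isopropyl in place of chloro on an aromatic carbon at the same place; the difference between the two cores is not broken down here. The step of a number no higher from compound 3 to compound 4 (the limit leaves the size open) is expected to stay unreadable, since the earlier pair both rest on the limit. Compound 4 is therefore estimated at 200000 nM, between 100000 nM and 1000000 nM, most likely again only a limit.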

Compound 4, half-maximal inhibitory concentration: > 200000 nM
Compound 4: no number, only a limit; the forecaster's own chance of this, stated with the estimate: 85%; the middle value lies on the limit itself.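

Compound 3 and compound 4 both rest on a limit, not a number, so no step between them can be read: the limit of > 200000 nM in this assay, at which 4 of the 4 values shown sit.

The compounds shown leave open whether isopropyl in place of chloro changes inhibition at all in this assay.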